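This account rests on a few compounds, and the source may have more. Where it says the series, first, only, none or still open, it means among the compounds named here.

Measured so far in a functional assay on the whole organism (strain Swiss albino) for inhibition, with Mus musculus as the target, in the writhing test, with stated times of 60 min and 15 min, at a dose of 100 mg/kg by the oral route; on this read-out lower numbers stand for less inhibition and higher numbers for more inhibition at the one dose given (going by the name of the read-out):
compound 1 `CNC(=O)CC1CCc2cc(OC)c(OC)cc21` gives 21.2%
compound 2 `COc1cc2c(cc1OC)C(CC(=O)NC(C)(C)C)CC2` gives 41.8%

Compound 2 stands highest of the two numbers in this assay, the nearest being compound 1, with a number 20.6 percentage points higher from compound 1 to compound 2 (beyond the scatter) separating them. Compound 3 `COc1cc2c(cc1OC)C(CC(=O)NC1CCCCC1)CC2` differs from compound 2 by cyclohexyl in place of tert-butyl on an amide-type nitrogen. For the measured compounds named here, the only measured step bearing on this nitrogen is a number 20.6 percentage points higher from compound 1 to compound 2 (beyond the scatter), a modest gain on enlarging the group there; no step from tert-butyl to a ring is available. On that basis a small further rise or no change beyond the scatter is expected, a number 5.2 percentage points higher from compound 2 to compound 3 (within the scatter). Compound 3 is therefore estimated at 47%, in the range 30% to 64%.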

Compound 3, a percentage reported as inhibition, in the whole organism at one dose (the size of the read-out at that dose, not a potency): 44.7%
Compound 3: middle estimate off by 2.3 percentage points, on the high side; measured number inside the range.
By their numbers in this assay, from the lowest: compound 1; then compounds 2 and 3 (each within the scatter of the next).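

In this assay, cyclohexyl in place of tert-butyl on the amide-type nitrogen gives a number 2.9 percentage points higher from compound 2 to compound 3 (within the scatter) and so does not separate the two groups. The gain over methyl is therefore not confined to tert-butyl, since a number 23.5 percentage points higher from compound 1 to compound 3 (beyond the scatter) holds for a group with a six-membered ring. No available evidence bears on either step.

Open, going by these compounds, is how phenyl, benzyl or a longer chain such as n-butyl on this nitrogen would read. Also open, on these data alone, is whether the amide hydrogen is needed, which an added methyl on the same nitrogen would address.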